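Chloro removal on the carboxyphenyl end of a bis-ether series

This account rests on a few compounds, and the source may have more. Where it says the series, first, only, none or still open, it means among the compounds named here.

Measured so far:
- compound 1 `COc1cc(C(=O)O)ccc1OCCCCOc1ccc(C(=O)CC(C)C)c(O)c1C` gives 73.9% in an assay on HEK293 cells for positive allosteric modulation of metabotropic glutamate receptor 3 (Rattus norvegicus), read by thallium flux, with a stated time of 2.5 min; on this read-out higher numbers stand for larger maximal responses and lower numbers for smaller maximal responses
- compound 2 `Cc1c(OCCCCOc2ccc(C(=O)O)c(Cl)c2)ccc(C(=O)CC(C)C)c1O` gives 49.5% in this assay

Within the data shown here, compound 2 stands lowest of the two numbers in this assay; the only comparator is compound 1, whose number is higher by more than the usual scatter. Among the measured compounds shown here, no pair differing in one place has been measured, so nothing is known yet about how a single substituent swap moves the largest response.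

Compound 3 `Cc1c(OCCCCOc2ccc(C(=O)O)cc2)ccc(C(=O)CC(C)C)c1O` is the next step from compound 2 and differs from it by hydrogen in place of chloro on an aromatic carbon. The two measured compounds differ at several places at once, so the effect of losing the chloro cannot be read from them; the step from compound 2 to compound 3 is therefore a guess from the pair alone.

The expectation is a small step, a number 8.5 percentage points higher from compound 2 to compound 3 (within the scatter), more likely upward than downward but not clearly beyond the scatter. Compound 3 is estimated at 58%, with a range from 40% to 78%.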

Compound 3, largest response reached (reported as percent of maximum), in percent of the reference or control that the assay uses: 51.9%
Compound 3: the middle estimate sits 6.1 percentage points above what was measured, and the stated range covers the measured number.
By their numbers in this assay, from the lowest: compounds 2 and 3 (each within the scatter of the next); then compound 1.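

In this assay, the chloro ortho to a carboxy group gives way to hydrogen without a difference that stands clear of repeat measurements, a number 2.4 percentage points higher from compound 2 to compound 3 (within the scatter), so this position on the carboxyphenyl end tolerates either atom on this read-out. Among these compounds, the methoxy of compound 1 is the first single change that clearly matters: hydrogen in its place gives a number 22 percentage points lower from compound 1 to compound 3 (beyond the scatter), which shows that the largest response can respond to one substituent on this ring, while the chloro swap does not show this. No supporting data bear on why one swap registers and the other does not.

Among the compounds shown here, it remains open whether a fluoro, a nitrile or a methoxy ortho to the carboxy group would stay level with compound 3 or rise toward compound 1, since chloro and hydrogen are the only two groups compared at that place. Also open, as far as these compounds go, is whether the methoxy step holds with a longer chain between the two ethers, or with an amide in place of the carboxylic acid.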